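The compounds below may be only part of what the source reports. "The series", "measured", "known", "first", "only" and "open" are said of these compounds alone.

Measured so far:
compound 1, `COc1cc(CNC(=S)NC(CCc2ccc(C(C)(C)C)cc2)COC(=O)C(C)(C)C)ccc1O`, with 36.5 nM in an assay on CHO cells for displacement of a labelled ligand from transient receptor potential cation channel subfamily V member 1 (Rattus norvegicus); on this read-out lower numbers stand for stronger inhibition and higher numbers for weaker inhibition;
compound 2, `COc1cc(CNC(=S)NCC(COC(=O)C(C)(C)C)Cc2ccc(C)c(C)c2)c(Br)cc1O`, with 19.9 nM in this assay.

The numbers of compound 1 and compound 2 lie within the usual scatter of one another, so neither can be called the stronger binder on this evidence. Compound 3, `COc1cc(CNC(=S)NC(CCc2ccc(C(C)(C)C)cc2)COC(=O)C(C)(C)C)c(Br)cc1O`, has not yet been measured. It differs from compound 1 by bromo in place of hydrogen on an aromatic carbon. Within the data shown here, no pair of measured compounds shows this change alone, so its effect is unknown. The step from compound 1 to compound 3 is estimated at a 1.7-fold lower number from compound 1 to compound 3 (0.22 log units; within the scatter), a modest move toward a lower number. Compound 3 is therefore expected to give about 22 nM, within 8 nM to 60 nM.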

Compound 3, inhibition constant: 75 nM
Compound 3: the middle estimate sits 3.4-fold (0.53 log units) below what was measured, outside the stated range (above it).
By their numbers in this assay, from the lowest: compounds 2 and 1 (each within the scatter of the next); then compound 3.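

Placing bromo on this aromatic carbon, ortho to a large group, can now be read directly: in this assay the change gives a 2.1-fold higher number from compound 1 to compound 3 (0.31 log units; beyond the scatter). On the core of compound 1, the 2-bromo-4-hydroxy-5-methoxybenzyl group therefore binds modestly more weakly than the 4-hydroxy-3-methoxybenzyl group. Nothing at hand offers an explanation for this shift. Going by these compounds, whether chloro or a methyl group on this carbon would give a similar step remains open, and one pair cannot show whether bromo would act alike with other side chains.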